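This account rests on a few compounds, and the source may have more. Where it says the series, first, only, none or still open, it means among the compounds named here.

Three compounds in this set have numbers in an in vitro functional assay on HEK293-A cells for negative allosteric modulation of metabotropic glutamate receptor 5 (Homo sapiens), read by FLIPR and calcium flux; on this read-out lower numbers stand for stronger inhibition and higher numbers for weaker inhibition. Compound 1 `O=C1CC(c2nc(-c3cccc(Cl)c3)no2)CN1c1ccccc1Cl` gives 680 nM in this assay. Compound 2 `O=c1sc2ccccc2n1Cc1nc(-c2cccc(Cl)c2)no1` gives 1100 nM in this assay, and compound 3 `O=c1oc2ccccc2n1Cc1nc(-c2cccc(Cl)c2)no1` gives 2100 nM in this assay. Compound 1 sits at the low end of the three numbers; its gap to compound 2 lies within the usual scatter, and only compound 3 stands beyond the scatter above it. For the measured compounds named here, no pair among the three differs in a single place, so no step can be read from the measured compounds.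

Compound 4 `O=C1CC(c2nc(-c3cccc(Cl)c3)no2)CN1c1cccc(Cl)c1` is not yet measured. It differs from compound 1 by 3-chlorophenyl in place of 2-chlorophenyl on an amide-type nitrogen in a ring. The measured compounds give no step of this kind, so the size and direction of the change rest on nothing shown here. The step expected a 1.0-fold higher number from compound 1 to compound 4 (0.01 log units; within the scatter) is therefore none beyond the scatter. For compound 4 in this assay the estimate is 700 nM, with a range from 250 nM to 2000 nM.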

Compound 4, half-maximal inhibitory concentration: 1100 nM
Estimate against measurement, compound 4: 1.6-fold (0.20 log units) below, and the stated range covers the measured number.
By their numbers in this assay, from the lowest: compounds 1, 2, 4 and 3 (each within the scatter of the next, the first and the last beyond it).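

In this assay, for the compounds shown here, 3-chlorophenyl in place of 2-chlorophenyl on the amide-type nitrogen in the ring gives a 1.6-fold higher number from compound 1 to compound 4 (0.21 log units; within the scatter), the first step in the set that can be read at this position. On the core of compound 1, this read-out therefore does not separate the two chlorophenyl groups, and the pair gives no sign that the place of the chlorine on this ring matters. No supporting data accompany this pair, so the result comes with no explanation.

Open, from the compounds shown here alone, is how a 4-chlorophenyl, a plain phenyl or a cyclohexyl on the same nitrogen would compare with the two chlorophenyl groups. Also open, going by these compounds, is whether a methoxy group or a nitrile in place of the chlorine would keep the number in the same range.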